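Trifluoromethyl in Place of Nitro: An Expected Potency

This account rests on a few compounds, and the source may have more. Where it says the series, first, only, none or still open, it means among the compounds named here.

Compound 3 `CCOc1ccc(C(=O)/C=C/c2ccc([N+](=O)[O-])cc2)cc1` was tested in an assay on isolated protein for inhibition of Amine oxidase [flavin-containing] B (Homo sapiens) (a higher number here means a weaker inhibitor, a lower number a stronger inhibitor), where compound 3 gives 210 nM. Compound 1 `CCOc1ccc(C(=O)/C=C/c2ccc(Br)cc2)cc1` carries bromo where compound 3 carries nitro, and in this assay compound 1 gives 210 nM. For the measured compounds named here, the step of no change at the digits printed from compound 1 to compound 3 (within the scatter) shows that exchanging bromo for nitro on this aromatic carbon leaves the half-maximal inhibitory concentration where it was, so compound 3 stands level with compound 1, and these two are the only full numbers in the set. Compound 2 `O=C(/C=C/c1ccc(C(F)(F)F)cc1)c1ccc(-n2ccnc2)cc1` also carries trifluoromethyl but differs from compound 4 elsewhere in the molecule; in this assay compound 2 gives > 10000 nM, which is a limit of the assay and not a number.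

Compound 4 `CCOc1ccc(C(=O)/C=C/c2ccc(C(F)(F)F)cc2)cc1` has not yet been measured. It differs from compound 3 by trifluoromethyl in place of nitro on an aromatic carbon. Going by the values given here, the one measured step at this position, no change at the digits printed from compound 1 to compound 3 (within the scatter), was flat, so the step of a 1.4-fold higher number from compound 3 to compound 4 (0.15 log units; within the scatter) is expected to be small as well, with no direction beyond the scatter. Compound 4 is therefore estimated at 300 nM, with a range from 80 nM to 1500 nM. Because of the limit of > 10000 nM in this assay, at which 1 of the 3 values shown sits, the upper end of that range is set wide.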

Compound 4, half-maximal inhibitory concentration: 210 nM
Compound 4: middle estimate off by 1.4-fold (0.15 log units), on the high side; measured number inside the range.
By their numbers in this assay, from the lowest: compounds 1, 3 and 4 (each within the scatter of the next). At a limit, above all of these: compound 2.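

With trifluoromethyl, the position now holds three different groups on the same core, and the number in this assay does not separate them: the step to the new group shows no change at the digits printed from compound 3 to compound 4 (within the scatter), and the comparison with bromo shows no change at the digits printed from compound 1 to compound 4 (within the scatter). Trifluoromethyl has none of the hydrogen-bond acceptors counted for nitro, yet this exchange stays within the scatter, so on these compounds the flat result is no longer tied to a single pair. Compound 4 also gives compound 2 its first partner differing in one place, with trifluoromethyl shared by both, and the exchange at the other end of the molecule gives an at least 47-fold lower number from compound 2 to compound 4 (1.67 log units; beyond the scatter), a size that is only a bound since compound 2 stands at a limit of the assay: the limit of > 10000 nM in this assay, at which 1 of the 4 values shown sits.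

On these data alone, all three groups at this position leave the number level, so it remains open whether an amine or a carboxylic acid there would do the same. At the other end, only ethoxy and 1H-imidazol-1-yl are compared, which leaves open how a longer chain in place of ethoxy would read.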